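The compounds below may be only part of what the source reports. "The series", "measured", "known", "first", "only" and "open" are said of these compounds alone.

Measured compounds:
- compound 1, `Cc1cc(NC(=S)Cn2nnc(-c3ccccc3)n2)n(C2CCCCC2)n1`: 623 nM
- compound 2, `Cc1cc(NC(=O)Cn2nnc(-c3ccc(Cl)c(Cl)c3)n2)n(C2CCCCC2)n1`: 1220 nM

Both were run in an assay on HEK293 cells for activation of Kir3.1/Kir3.2 (Homo sapiens), read by thallium flux; a lower number here means that less compound is needed, a higher number that more compound is needed for the effect. Of the two numbers, that of compound 2 is the larger, but its gap to compound 1 lies within the usual scatter, so the two are not distinguished.

Compound 3, `Cc1cc(NC(=O)Cn2nnc(C3CC3)n2)n(C2CCCCC2)n1`, has not yet been measured. It differs from compound 2 by cyclopropyl in place of 3,4-dichlorophenyl on an aromatic carbon. Going by the values given here, no comparable step between measured compounds exists in this set, so the size of the change must be guessed. Compound 3 is expected to need more compound than compound 2, with a step of a 2.9-fold higher number from compound 2 to compound 3 (0.46 log units; beyond the scatter) that is likely beyond the scatter. Compound 3 is therefore estimated at 3500 nM, in the range 1000 nM to 12000 nM.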

Compound 3, half-maximal effective concentration: > 3000 nM
Compound 3: a limit, no number; the forecaster's own chance of this, stated with the estimate: 25%; the middle value lies beyond the limit too.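

Going by these compounds alone, replacing 3,4-dichlorophenyl with cyclopropyl on this aromatic carbon gives the first step that can be read beyond the scatter: in this assay the change gives an at least 2.4-fold higher number from compound 2 to compound 3 (0.39 log units; beyond the scatter). This position is therefore not indifferent to the group it carries. The result for compound 3 is a limit of the assay and not a number, so the step has no upper end: the limit of > 3000 nM in this assay, at which 1 of the 3 values shown sits.

Still open, from the compounds shown here alone, is how a plain phenyl, a 4-chlorophenyl or a longer chain such as n-butyl would fare at this position on the core of compound 2. It also remains unclear whether the step follows the aromatic ring or the two chlorine atoms.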